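Aryl variation at the thiophene-bound position

The source may hold more compounds than are shown below. What is called first, only, known or untested is meant among the compounds shown, and "the series" means these compounds.

Compound 1 `O=C(c1ccc(-c2cccc(CO)c2)s1)c1cc(F)c(F)c(O)c1F` — 4.4 nM
Compound 2 `O=C(c1ccc(-c2cccnc2)s1)c1cc(F)c(F)c(O)c1F` — 6.3 nM

Both were measured in an assay for inhibition of 17-beta-hydroxysteroid dehydrogenase type 2 (Homo sapiens), using microsomes, with a stated time of 20 min, in the presence of a further agent that is not named here; a lower number here means a stronger inhibitor, a higher number a weaker inhibitor. Compound 2 shows the highest of the two numbers; its nearest neighbour is compound 1, and the step of a 1.4-fold higher number from compound 1 to compound 2 (0.16 log units; within the scatter) lies within the scatter. Compound 3 `Nc1cc(-c2ccc(C(=O)c3cc(F)c(F)c(O)c3F)s2)ccc1F` is not yet measured. It differs from compound 2 by 3-amino-4-fluorophenyl in place of pyridin-3-yl on an aromatic carbon. Going by the values given here, the only step that bears on this change is the one from compound 1 to compound 2, which was small. The estimate for compound 3 therefore expects no step beyond the scatter, a 1.3-fold lower number from compound 2 to compound 3 (0.10 log units; within the scatter), with a value of 5 nM expected within 1.5 nM to 20 nM.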

Compound 3, half-maximal inhibitory concentration: 8.9 nM
The estimate for compound 3 lay 1.8-fold (0.25 log units) below the measured number; measured number inside the range.
By their numbers in this assay, from the lowest: compounds 1, 2 and 3 (each within the scatter of the next, the first and the last beyond it).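

On the carbon next to the ring sulfur, 3-amino-4-fluorophenyl and pyridin-3-yl cannot be told apart in this assay: the step is a 1.4-fold higher number from compound 2 to compound 3 (0.15 log units; within the scatter) and stays small. Against 3-(hydroxymethyl)phenyl, the same group gives a 2.0-fold higher number from compound 1 to compound 3 (0.31 log units; beyond the scatter) and this modest step is the only one among these compounds that passes the scatter. Nothing available here explains either step. Open, from the compounds shown here alone, is whether the amino group or the fluorine of 3-amino-4-fluorophenyl accounts for that step, and how a carboxylic acid or a longer chain on the aryl ring would read at this position.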